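Caffeic amides: removing the carbamate from the piperazine amide

The compounds below may be only part of what the source reports. "The series", "measured", "known", "first", "only" and "open" are said of these compounds alone.

Among the compounds with values here, two caffeic amides have numbers so far. Compound 1 `Cc1ccc(CNC(=O)/C=C/c2ccc(O)c(O)c2)cc1` gives 22% in an ADME assay on B16 cells (Mus musculus) for cytotoxicity, read by MTT assay, tested at 20 uM; a lower number here means a weaker effect, a higher number a stronger effect of the compound at the concentration tested. Compound 2 `CC(C)(C)OC(=O)N1CCN(C(=O)/C=C/c2ccc(O)c(O)c2)CC1` gives 31% in this assay. Compound 2 stands highest of the two numbers, with compound 1 nearest at a value nine points lower, a gap within the scatter, so the two read as alike. Within the data shown here, no step between measured compounds that differ in one place is available, and the series gives no guide to the size of any single change.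

Compound 3 `O=C(/C=C/c1ccc(O)c(O)c1)N1CCNCC1` is not yet measured. It differs from compound 2 in one place: hydrogen in place of tert-butoxycarbonyl on an amine nitrogen in a ring. With nothing comparable measured, the step from compound 2 to compound 3 is expected to be small, downward, and not clearly beyond the scatter, a number 9 percentage points lower from compound 2 to compound 3 (within the scatter). Compound 3 is estimated at 22% in this assay, with a range from 6% to 40%.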

Compound 3, a percentage reported as activity, at one concentration (the size of the read-out at that concentration, not a potency): 31%
Estimate against measurement, compound 3: 9 percentage points below, within the range that was stated.
By their numbers in this assay, from the lowest: compounds 1, 2 and 3 (each within the scatter of the next).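

In this assay, the series now has its first readable single-place change: no change at the digits printed from compound 2 to compound 3 (within the scatter) with hydrogen in place of tert-butoxycarbonyl on an amine nitrogen in a ring. At this position, the read-out at the concentration tested therefore does not depend on keeping the tert-butoxycarbonyl group, and its 7 heavy atoms can go without a step beyond the scatter. No supporting data bear on this result.

The compounds shown leave open whether other groups on this nitrogen, such as methyl, acetyl, a longer alkyl chain or a chain ending in a carboxylic acid, would also stay within the scatter. They also leave open whether the same replacement would give a similar step on a different amide of the series.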